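Pyrrole in place of furan on the hydrazide of compound 3

This account rests on a few compounds, and the source may have more. Where it says the series, first, only, none or still open, it means among the compounds named here.

Compound 1 `CCNC(=O)[C@H]1O[C@@H](n2cnc3c(NNC(=O)c4ccc(Cl)cc4)ncnc32)[C@H](O)[C@@H]1O`: in an assay on CHO cells for displacement of a labelled ligand from adenosine receptor A1 (Homo sapiens) (a lower number here means a stronger inhibitor, a higher number a weaker inhibitor), compound 1 reaches only an assay limit, > 5000 nM.
Compound 2 `CCNC(=O)[C@H]1O[C@@H](n2cnc3c(NNC(=O)c4cccnc4)ncnc32)[C@H](O)[C@@H]1O`: in this assay compound 2 likewise gives a limit, > 5000 nM.
Compound 3 `CCNC(=O)[C@H]1O[C@@H](n2cnc3c(NNC(=O)c4ccco4)nc(Cl)nc32)[C@H](O)[C@@H]1O`: in this assay compound 3 gives 3500 nM.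

For the measured compounds named here, compound 3 holds the only measured number in this assay; the other two values are limits, as recorded in the limit of > 5000 nM in this assay, at which 2 of the 3 values shown sit. The step that the two limits leave unreadable from compound 1 to compound 2 cannot be sized, as both of its ends are limits and it concerns pyridin-3-yl for 4-chlorophenyl. Compound 4 `CCNC(=O)[C@H]1O[C@@H](n2cnc3c(NNC(=O)c4ccc[nH]4)nc(Cl)nc32)[C@H](O)[C@@H]1O` differs from compound 3 by 1H-pyrrol-2-yl in place of furan-2-yl on a carbonyl carbon. Going by the values given here, no measured step covers this exchange, and nothing in the set points in either direction. The change is therefore expected to move the inhibition constant in this assay little, within the usual scatter. Compound 4 is expected to give about 3500 nM, between 1200 nM and 10000 nM. The expected step of no change at the digits printed from compound 3 to compound 4 (within the scatter) is small. Because compound 3 gives 3500 nM near the edge of the measurable range, compound 4 may also fall outside that range.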

Compound 4, inhibition constant: 610 nM
Beside the measured number, compound 4's estimate is 5.7-fold (0.76 log units) above it; the measured number lies below the stated range.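

In this assay, for the compounds shown here, the ring on this carbonyl carbon of the hydrazide clearly affects the result: 1H-pyrrol-2-yl in place of furan-2-yl gives a 5.7-fold lower number from compound 3 to compound 4 (0.76 log units; beyond the scatter), the first readable step. The two rings are both five-membered and aromatic with the same count of heavy atoms, and the exchange replaces a ring oxygen, counted as a hydrogen-bond acceptor, with a ring nitrogen carrying a hydrogen-bond donor; that difference alone is enough to move the number beyond the scatter. Nothing measured here accounts for the step.

On these data alone, whether the hydrogen on the pyrrole nitrogen matters stays open, and a 1-methylpyrrol-2-yl group on the same carbonyl carbon would test this. The step between compound 1 and compound 2 cannot be read, as each gives only a limit.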